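The source may hold more compounds than are shown below. What is called first, only, known or untested is meant among the compounds shown, and "the series" means these compounds.

Series notes. Among the measured compounds shown here, compound 1 `CC(C)(C)c1ccc(C(=O)N2CCC3(CC2)C(=O)N(CC(=O)NCCC(=O)O)CN3c2ccccc2)cc1` and compound 2 `CC(C)(C)OC(=O)NCC1CCN(C(=O)CN2CN(c3ccccc3)C3(CCN(C(=O)c4ccc(C(C)(C)C)cc4)CC3)C2=O)CC1` share the core, and in an assay on HEK293 cells for displacement of a labelled ligand from NPC1-like intracellular cholesterol transporter 1 (Homo sapiens) (on this read-out higher numbers stand for weaker inhibition and lower numbers for stronger inhibition), compound 1 gives 11400 nM, the highest of the two numbers measured so far; compound 2 gives 4200 nM, a lower number, a gap beyond the usual scatter. Compound 3 `CC(C)(C)c1ccc(C(=O)N2CCC3(CC2)C(=O)N(CC(=O)NCCCCN)CN3c2ccccc2)cc1` differs from compound 1 only in the chain on the amide-type nitrogen: 2-aminoethyl in place of carboxy on a saturated chain carbon, two bonds along the chain from an amide-type nitrogen. For the measured compounds named here, no measured pair in this set carries the same change, so the direction rests on the structures alone. For compound 3 the step of a 1.9-fold lower number from compound 1 to compound 3 (0.28 log units; within the scatter) is expected to be modest and toward a lower number. Compound 3 is estimated at 6000 nM, within 2000 nM to 20000 nM.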

Compound 3, half-maximal inhibitory concentration: 14500 nM
Estimate against measurement, compound 3: 2.4-fold (0.38 log units) below, and the stated range covers the measured number.
By their numbers in this assay, from the lowest: compound 2; then compounds 1 and 3 (each within the scatter of the next).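

At the end of the chain on the shared core, 2-aminoethyl in place of carboxy, on a saturated chain carbon, two bonds along the chain from an amide-type nitrogen, gives a 1.3-fold higher number from compound 1 to compound 3 (0.10 log units; within the scatter) in this assay and stays within the scatter. On this single pair, the read-out does not separate a carboxy end from an amine end at this position. Nothing at hand accounts for this. Still open, from the compounds shown here alone, is whether a hydroxyl or a primary amide at this chain end reads differently, and whether a shorter or longer chain carrying the same amine or carboxylic acid moves the number beyond the scatter.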